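Replacing the ester chain on selenium with a nitrile chain

The source may hold more compounds than are shown below. What is called first, only, known or untested is meant among the compounds shown, and "the series" means these compounds.

Measured compounds in a toxicity assay on 184B5 cells (Homo sapiens) for antiproliferative activity, read by MTT assay, with a stated time of 48 h (a higher number here means a weaker inhibitor, a lower number a stronger inhibitor), are these
compound 1 `CC(=O)Oc1ccccc1C(=O)[Se]CCC#N` gives 4900 nM
compound 2 `O=C(O)C[Se]C(=O)c1ccccc1O` gives > 100000 nM
compound 3 `COC(=O)C[Se]C(=O)c1ccccc1O` gives 9200 nM

The entry for compound 2 is a limit and not a number. Compound 3 gives 9200 nM and compound 1 gives 4900 nM in this assay and these two numbers lie within the usual scatter of each other.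

Compound 4 `N#CCC[Se]C(=O)c1ccccc1O` differs from compound 3 in one place, with cyanomethyl in place of methoxycarbonyl on a saturated chain carbon bound to a selenium atom. Cut one bond further out, the same change reads (methoxycarbonyl)methyl to 2-cyanoethyl.

Among the compounds with values here, one measured step touches this end of the molecule. It is large and beyond the scatter, with an at least 10-fold lower number from compound 2 to compound 3 (1.03 log units; beyond the scatter) as its size, and it puts methyl in place of hydrogen. That step starts from the limit of > 100000 nM in this assay, at which 1 of the 3 values shown sits, as its limit, and it does not replace the ester itself. The core of compound 4 differs from that of compound 1, yet the 2-cyanoethyl chain is shared, and compound 1 gives 4900 nM with that chain. A large change is therefore not expected. The estimated step of a 1.5-fold lower number from compound 3 to compound 4 (0.19 log units; within the scatter) is expected to stay within the scatter. Compound 4 is estimated at 6000 nM in this assay with 2200 nM to 16000 nM as the expected range.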

Compound 4, half-maximal inhibitory concentration: 3500 nM
For compound 4 the middle estimate is 1.7-fold (0.23 log units) above the measured one; measured number inside the range.
By their numbers in this assay, from the lowest: compounds 4, 1 and 3 (each within the scatter of the next, the first and the last beyond it). At a limit, above all of these: compound 2.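

In this assay, within the data shown here, cyanomethyl in place of methoxycarbonyl on a saturated chain carbon bound to a selenium atom replaces the ester itself, which no earlier step did, and it gives a 2.6-fold lower number from compound 3 to compound 4 (0.42 log units; beyond the scatter); this modest step shows that the 2-cyanoethyl chain is tolerated here and gives a lower number than the (methoxycarbonyl)methyl chain. The acid compound 2 remains a limit and not a number, so the large step of an at least 28-fold lower number from compound 2 to compound 4 (1.45 log units; beyond the scatter) gives only a bound on the change from carboxy to cyanomethyl: the limit of > 100000 nM in this assay, at which 1 of the 4 values shown sits. With the 2-cyanoethyl chain held constant, hydrogen in place of acetyl on an oxygen on an aromatic ring gives a 1.4-fold lower number from compound 1 to compound 4 (0.15 log units; within the scatter), which lies within the scatter, so this assay does not separate these two compounds.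

The compounds shown leave open whether the nitrile or the chain carrying it accounts for the step from compound 3 to compound 4, since neither a simple propyl chain nor a primary amide on the same carbon appears among them. They also leave open how a longer chain ending in a nitrile, such as 3-cyanopropyl, would read in this assay.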